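From thiophen-3-yl to 1-methyl-1H-pyrazol-5-yl on the amide

This account rests on a few compounds, and the source may have more. Where it says the series, first, only, none or still open, it means among the compounds named here.

Measured so far in a functional assay on MKN-7 cells (Homo sapiens) for inhibition, read by colorimetric assay and sulforhodamine B assay, with a stated time of 48 h (on this read-out higher numbers stand for weaker inhibition of growth and lower numbers for stronger inhibition of growth), as the read-out:
- compound 1 `CCCCCCCCCCCC[C@@H](O)[C@H]1CC[C@H]([C@H](O)CCCCCCCCCCNC(=O)c2ccco2)O1` with 832 nM as its value
- compound 2 `CCCCCCCCCCCC[C@@H](O)[C@H]1CC[C@H]([C@H](O)CCCCCCCCCCNC(=O)c2ccsc2)O1` with 170 nM as its value

Compound 2 has the lower of these two numbers and so shows the stronger inhibition of growth. Compound 3 `CCCCCCCCCCCC[C@@H](O)[C@H]1CC[C@H]([C@H](O)CCCCCCCCCCNC(=O)c2ccnn2C)O1` has not yet been measured. It carries 1-methyl-1H-pyrazol-5-yl in place of thiophen-3-yl on a carbonyl carbon. A single measured step bears on this change (a 4.9-fold lower number from compound 1 to compound 2 (0.69 log units; beyond the scatter)). That step exchanged furan-2-yl for thiophen-3-yl at the same place, and it shows that the group on this carbonyl carbon can move the number beyond the scatter. No pyrazole has been measured, so this one modest step gives only a rough guide to size. A move to a higher number is expected, of similar modest size to that measured step, and the estimated change is (a 2.8-fold higher number from compound 2 to compound 3 (0.45 log units; beyond the scatter)). Compound 3 is therefore expected at 480 nM within an estimated range of 160 nM to 1400 nM in this assay testing.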

Compound 3, concentration for 50% growth inhibition: 10 nM
Estimate against measurement, compound 3: 48-fold (1.68 log units) above; the whole stated range lies above it.
By their numbers in this assay, from the lowest: compound 3; then compound 2; then compound 1.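

In this assay, the change to 1-methyl-1H-pyrazol-5-yl gives a 17-fold lower number from compound 2 to compound 3 (1.23 log units; beyond the scatter) and, measured against the furan-2-yl amide, an 83-fold lower number from compound 1 to compound 3 (1.92 log units; beyond the scatter) as well, so this place on the carbonyl carbon can shift the number much further than the earlier exchange of one ring for another, a 4.9-fold lower number from compound 1 to compound 2 (0.69 log units; beyond the scatter), had shown. All three compounds carry a five-membered aromatic ring here and differ only in that ring, so having such a ring does not by itself set the number, and compound 3 is the most potent of the three, with both of its steps beyond the scatter. Nothing given here accounts for the size of this drop.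

As far as these compounds go, the three compounds do not separate the contribution of the pyrazole ring from that of its methyl group, so it remains open how an unsubstituted pyrazole or an ethyl group in place of that methyl would read. They also leave open whether a six-membered ring such as pyridine or phenyl on the same carbonyl carbon would hold the number as low as compound 3 does.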